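Bromo for hydroxy in an inactive hydrazone pair

A few compounds are considered here, and "the series" means these few. Any claim that something is new, unique, unknown or untested is made for them only; others in the source may bear on it.

Measured in a functional assay on SMMC-7721 cells (Homo sapiens) for antiproliferative activity, read by MTT assay, with a stated time of 72 h; a higher number here means a weaker inhibitor, a lower number a stronger inhibitor:
Compound 1 `C/C(=N\NC(=O)c1cccc(S(=O)(=O)N2CCOCC2)c1)c1cccc(O)c1`: > 100000 nM
Compound 2 `C/C(=N\NC(=O)c1cccc(S(=O)(=O)N2CCOCC2)c1)c1cc(O)ccc1O`: > 100000 nM

Neither entry is a number; each is a limit of the assay. Compound 2 therefore has no measured potency, and it sits at the limit of > 100000 nM in this assay, at which 2 of the 2 values shown sit.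

The next compound, compound 3 `C/C(=N\NC(=O)c1cccc(S(=O)(=O)N2CCOCC2)c1)c1cc(Br)ccc1O`, changes one place on compound 2: bromo in place of hydroxy on an aromatic carbon. This is bromo in place of hydroxy on an aromatic carbon, para to a hydroxy group, so that 2,5-dihydroxyphenyl becomes 5-bromo-2-hydroxyphenyl.

For the measured compounds named here, only one measured step bears on this change, a step that the two limits leave unreadable from compound 1 to compound 2. It involves a hydroxy group, but it has no readable size and offers no measured guide to what bromo will do. Going by the values given here, no measured compound carries bromo. Any readable result in this assay would nevertheless have to lie on the stronger side of the limit, so a modest gain is expected, while a second limit remains quite possible. The expected change is an at least 3.3-fold lower number from compound 2 to compound 3 (0.52 log units; beyond the scatter). Compound 3 is estimated at 30000 nM, with an expected range from 3000 nM to 100000 nM.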

Compound 3, half-maximal inhibitory concentration: 2410 nM
For compound 3 the middle estimate is 12-fold (1.10 log units) above the measured one; measured number below the stated range.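

In this assay, putting bromo in place of hydroxy on the aromatic carbon para to a hydroxy group gives an at least 41-fold lower number from compound 2 to compound 3 (1.61 log units; beyond the scatter), the first readable potency in this set and the first sign that this position can shift the result. The same compound also stands apart from the 3-hydroxyphenyl compound, with 5-bromo-2-hydroxyphenyl on the carbon with a double bond to nitrogen giving an at least 41-fold lower number from compound 1 to compound 3 (1.61 log units; beyond the scatter), whereas the step between compound 1 and compound 2 cannot be read. Compound 2 has a limit of the assay and not a number, so the true size of the bromo step stays unknown: the limit of > 100000 nM in this assay, at which 2 of the 3 values shown sit.

The compounds shown leave open whether the gain goes with bromo itself or with the hydroxy group leaving, and chloro, methyl or an amine on the same carbon would bear on that question. Also open, as far as these compounds go, is what the hydroxy group that stays on the ring of compound 3 contributes, which a methoxy group in its place would test.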